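Replacement of the benzylamine in compound 1 by a piperidine

This account rests on a few compounds, and the source may have more. Where it says the series, first, only, none or still open, it means among the compounds named here.

Measured in a physicochemical assay for lipophilicity; on this read-out lower numbers stand for lower lipophilicity and higher numbers for higher lipophilicity:
compound 1 `COc1cccc(CNCc2c(-c3nnc(SC(C)C)n3-c3ccccc3)n(C)c3ccc(F)cc23)c1` 6.42
compound 2 `COc1cccc(CNCc2c(-c3nnc(SC(C)C)n3-c3ccccc3)n(C)c3ccccc23)c1` 6.27
compound 3 `CC1CN(Cc2c(-c3nnc(SC(C)C)n3-c3ccccc3)n(C)c3ccccc23)CC(C)O1` 5.13

Compound 1 has the highest number of the three; compound 2 sits within the scatter of it (a number 0.15 log units lower from compound 1 to compound 2 (within the scatter)), compound 3 well below. Compound 4 `CC1CCN(Cc2c(-c3nnc(SC(C)C)n3-c3ccccc3)n(C)c3ccc(F)cc23)CC1` keeps the fluoro of compound 1 and differs in one place: 4-methylpiperidin-1-yl in place of (3-methoxybenzyl)amino on a saturated chain carbon bound to an aromatic carbon. Among the compounds with values here, the step that bears on this is the one from compound 2 to compound 3, where a benzylamine gave way to a cyclic amine (a number 1.14 log units lower from compound 2 to compound 3 (beyond the scatter)). The ring entering here is not the same ring, so a drop of similar kind but somewhat smaller size is expected: a number 0.62 log units lower from compound 1 to compound 4 (beyond the scatter). For compound 4 in this assay the estimate is 5.8, between 5.3 and 6.3.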

Compound 4, partition coefficient: 6.12
Compound 4: middle estimate off by 0.32 log units, on the low side; the range from low to high includes it.
By their numbers in this assay, from the lowest: compound 3; then compounds 4, 2 and 1 (each within the scatter of the next).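

With 4-methylpiperidin-1-yl in place of (3-methoxybenzyl)amino on a saturated chain carbon bound to an aromatic carbon, this assay gives a number 0.30 log units lower from compound 1 to compound 4 (within the scatter), so this exchange leaves the read-out within the scatter. The step to 2,6-dimethylmorpholin-4-yl, a number 1.14 log units lower from compound 2 to compound 3 (beyond the scatter), therefore does not extend to every cyclic amine at this position. No measurement available here accounts for the contrast between the two rings. Still open, from the compounds shown here alone, is whether 4-methylpiperidin-1-yl gives a similar step on the core of compound 2, which lacks the fluoro. Going by these compounds, how an unsubstituted piperidine or a piperazine would read at this position also remains open.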